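The source may report more compounds than this note shows. Statements on the series, on what has been measured and on what is new or still open speak of the compounds shown alone.

Compound 1 `CCc1cc(C(C)=O)c(O)cc1OCCCCCCC#N` gives 73% in an assay on isolated protein for binding affinity to leukotriene B4 receptor 1 (Homo sapiens), tested at 1 uM; on this read-out lower numbers stand for less inhibition and higher numbers for more inhibition at the one concentration tested (going by the name of the read-out).
Compound 2 `CCc1cc(C(C)=O)c(O)cc1OCCCCCCCC(C)(C)C#N` gives 29% in this assay.
Compound 3 `CCc1cc(C(C)=O)c(O)cc1OCCCCCCC(C)(C)c1nnn[nH]1` gives 67% in this assay.

Compound 3 stands second highest of the three numbers in this assay; its step to compound 1 lies within the scatter, a number 6 percentage points lower from compound 1 to compound 3 (within the scatter), while its step from compound 2 is large, a number 38 percentage points higher from compound 2 to compound 3 (beyond the scatter).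

Compound 4 `CCc1cc(C(C)=O)c(O)cc1OCCCCCCSC` has not yet been measured. It differs from compound 3 in one place: methylsulfanyl in place of 1-(1H-tetrazol-5-yl)-1-methylethyl on a saturated chain carbon, six bonds along the chain from an oxygen on an aromatic ring.

Among the compounds with values here, two measured steps bear on this. The exchange of cyano for the tetrazolyl-bearing group hardly moved the read-out, a number 6 percentage points lower from compound 1 to compound 3 (within the scatter), whereas the bulkier cyano-bearing group cost much, a number 44 percentage points lower from compound 1 to compound 2 (beyond the scatter). Within the data shown here, both small end groups, cyano and the entering methylsulfanyl, carry one hydrogen-bond acceptor and no donor; no measured compound carries a sulfur, so the comparison rests on size alone. On that basis compound 4 is expected to land near compound 1 and compound 3 rather than near compound 2, with a step of a number 9 percentage points lower from compound 3 to compound 4 (within the scatter) expected from compound 3.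

Compound 4 is therefore estimated at 58% in this assay, expected between 30% and 80%.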

Compound 4, a percentage reported as inhibition, at one concentration (the size of the read-out at that concentration, not a potency): 14%
For compound 4 the middle estimate is 44 percentage points above the measured one; measured number below the stated range.
By their numbers in this assay, from the lowest: compound 4; then compound 2; then compounds 3 and 1 (each within the scatter of the next).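

In this assay, placing methylsulfanyl on a saturated chain carbon, six bonds along the chain from an oxygen on an aromatic ring, gives a number 59 percentage points lower from compound 1 to compound 4 (beyond the scatter) and a number 53 percentage points lower from compound 3 to compound 4 (beyond the scatter) as well. Heavy-atom count therefore does not sort the read-out at this position: the small cyano and the large 1-(1H-tetrazol-5-yl)-1-methylethyl both stand high, whereas the small methylsulfanyl and the large 2-cyano-2-methylpropyl both stand low. Compound 4 also lies clearly under the other low compound, with a number 15 percentage points lower from compound 2 to compound 4 (beyond the scatter), and nothing available explains why two such small end groups differ so widely.

The compounds shown leave open whether the sulfur itself matters, which a methoxy group at the same place would test, and whether a carboxylic acid there would stand with compound 1 and compound 3. They also leave open whether a longer chain carrying methylsulfanyl would stay as low as compound 4, since the four compounds give only a few points at this one position.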